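From 4-methoxyphenyl to cyclobutyl on the shared core

The compounds below may be only part of what the source reports. "The series", "measured", "known", "first", "only" and "open" are said of these compounds alone.

In a toxicity assay on Vero cells (Chlorocebus sabaeus) for cytotoxicity, read by MTT assay, with a stated time of 72 h (a lower number here means a stronger inhibitor, a higher number a weaker inhibitor), the measured compounds are these:
Compound 1 `CC(C)(C)c1nc2ccccc2n1C(=O)c1cccc2ccccc12` gives > 10000 nM as a limit
Compound 2 `COc1ccc(-c2nc3ccccc3n2C(=O)c2cccc3ccccc23)cc1` gives > 10000 nM as a limit

For compound 2 the reading > 10000 nM is a limit of the assay and not a number. Among the compounds with values here, the series so far shows the limit of > 10000 nM in this assay, at which 2 of the 2 values shown sit, and nothing more. Compound 3 `O=C(c1cccc2ccccc12)n1c(C2CCC2)nc2ccccc21` has cyclobutyl in place of 4-methoxyphenyl on an aromatic carbon, between two ring nitrogen atoms, and the change counts as cyclobutyl in place of 4-methoxyphenyl on an aromatic carbon in full. Within the data shown here, the only measured step that bears on it is a step that the two limits leave unreadable from compound 1 to compound 2 and it has no size to carry over. Since a step that the two limits leave unreadable from compound 1 to compound 2 gives no readable size, no readable step in either direction is expected in this assay for this change. The expected step, an estimate only, is a step that the limit leaves unreadable from compound 2 to compound 3 and the assay will probably report a limit again. For compound 3 the estimated value is 20000 nM with an expected range from 10000 nM to 60000 nM in this assay.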

Compound 3, half-maximal inhibitory concentration: > 10000 nM
Compound 3: a limit, no number; the forecaster's own chance of this, stated with the estimate: 90%; the middle value is on the limit's open side.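

No new step can be read among compound 1, compound 2 and compound 3 in this assay, as each reading is a limit of the assay and not a number: the limit of > 10000 nM in this assay, at which 3 of the 3 values shown sit.

The compounds shown leave open whether tert-butyl, 4-methoxyphenyl and cyclobutyl on the shared core differ at all in this assay.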